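Methoxy for hydrogen on an aroyl ring: a second look

The compounds below may be only part of what the source reports. "The series", "measured", "known", "first", "only" and "open" are said of these compounds alone.

Compound 1, `Cn1cc(-c2nc3ccccc3n2C(=O)c2ccccc2)c2ccccc21`, gives 19600 nM in a functional assay on A549 cells (Homo sapiens) for inhibition, read by MTT assay, with a stated time of 24 h; a lower number here means a stronger inhibitor of growth, a higher number a weaker inhibitor of growth. Compound 2, `COc1ccccc1C(=O)n1c(-c2cn(C)c3ccccc23)nc2ccccc21`, gives 12300 nM in this assay. Compound 3, `COc1ccc(C(=O)n2c(-c3cn(C)c4ccc(Br)cc34)nc3ccccc32)cc1`, gives 11300 nM in this assay.

Compounds 1 and 2 differ by methoxy in place of hydrogen on an aromatic carbon, a change that made a 1.6-fold lower number from compound 1 to compound 2 (0.20 log units; within the scatter). The difference between the core of compound 1 and the core of compound 3 is not broken down here; their values lie within the scatter of each other.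

Compound 4, `COc1ccc(C(=O)n2c(-c3cn(C)c4ccc(Br)cc34)nc3ccccc32)cc1OC`, carries the same kind of change relative to compound 3: methoxy in place of hydrogen on an aromatic carbon. Here the entering group sits ortho to a methoxy group and meta to a large group, whereas in compound 2 it sits ortho to a large group.

Because the earlier step, a 1.6-fold lower number from compound 1 to compound 2 (0.20 log units; within the scatter), stayed within the scatter, compound 4 is expected to give a 1.3-fold lower number from compound 3 to compound 4 (0.10 log units; within the scatter) in this assay. Compound 4 is estimated at 9000 nM, between 4000 nM and 20000 nM.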

Compound 4, concentration for 50% growth inhibition: 3400 nM
Compound 4: the middle estimate sits 2.6-fold (0.42 log units) above what was measured; measured number below the stated range.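

In this assay the change from 4-methoxyphenyl to 3,4-dimethoxyphenyl gave a 3.3-fold lower number from compound 3 to compound 4 (0.52 log units; beyond the scatter), a modest step. Set beside the step on the other core, it cannot be told apart from that earlier step: the same change on two cores in this assay, a 1.6-fold lower number (0.20 log units; within the scatter) from compound 1 to compound 2 and a 3.3-fold lower number (0.52 log units; beyond the scatter) from compound 3 to compound 4, 2.1-fold (0.32 log units) apart, within the scatter of two such steps. For the compounds shown here, this shows that the change lowered the number on both cores by amounts that agree within the scatter, but it does not establish a reliable gain across the series, since only two steps are available, only one lies beyond the scatter, and the entering methoxy sits in a different place in each.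

The compounds shown leave open whether an amine, a carboxylic acid or a longer chain at the same place would have a similar effect. They also leave open whether the same step would hold on the core of compound 1.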